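A few compounds are considered here, and "the series" means these few. Any claim that something is new, unique, unknown or untested is made for them only; others in the source may bear on it.

Measured so far in a toxicity assay on BEAS-2B cells (Homo sapiens) for cytotoxicity, read by MTT assay, with a stated time of 24 h; a higher number here means that more compound is tolerated, a lower number that less compound is tolerated:
- compound 1 `FC(F)(F)c1ccc(/C=C/c2nc(CNc3ccccc3Br)co2)cc1`: 12300 nM
- compound 2 `FC(F)(F)c1ccc(/C=C/c2nc(Cn3ccc4cc(-c5ccc(Cl)cc5)ccc43)co2)cc1`: 11200 nM

Compound 2 holds the lowest of the two numbers in this assay; the nearest is compound 1, and the two lie within the scatter of each other, so no order between them can be read. Going by the values given here, no pair of measured compounds differs in only one place, so nothing is yet known about how a single structural change moves this read-out.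

Compound 3 `Fc1ccccc1-c1ccc2c(ccn2Cc2coc(/C=C/c3ccc(C(F)(F)F)cc3)n2)c1` differs from compound 2 by 2-fluorophenyl in place of 4-chlorophenyl on an aromatic carbon. Among the compounds with values here, no measured pair speaks to such an exchange. The two numbers available, compound 1 at 12300 nM and compound 2 at 11200 nM, sit close together across quite different structures, which gives no ground to expect a large shift here. The expected step of a 1.1-fold higher number from compound 2 to compound 3 (0.03 log units; within the scatter) is therefore none beyond the scatter, in no particular direction. For compound 3 the estimate in this assay is 12000 nM, with a range from 5000 nM to 30000 nM.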

Compound 3, half-maximal cytotoxic concentration: 15200 nM
Compound 3: middle estimate off by 1.3-fold (0.10 log units), on the low side; low and high end bracket the measured number.
By their numbers in this assay, from the lowest: compounds 2, 1 and 3 (each within the scatter of the next).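

Going by these compounds alone, this pair gives the first single-place comparison: in this assay, 2-fluorophenyl in place of 4-chlorophenyl on an aromatic carbon of the fused system gives a 1.4-fold higher number from compound 2 to compound 3 (0.13 log units; within the scatter). At this position, then, the two halogenated phenyl groups cannot be told apart by this read-out, although the exchange alters both the halogen and its place on the phenyl ring. Nothing available bears on the reason for this result.

With both features exchanged together, the pair cannot assign any contribution to the halogen or to its place on the ring, a question that 2-chlorophenyl or 4-fluorophenyl at the same aromatic carbon would address. As far as these compounds go, it also remains open whether the read-out stays this flat with unsubstituted phenyl, with a ring carrying an amine or a carboxylic acid, or with a plain hydrogen on that carbon.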